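This account rests on a few compounds, and the source may have more. Where it says the series, first, only, none or still open, it means among the compounds named here.

Measured so far in an assay on COS-7 cells for inhibition of sodium/nucleoside cotransporter 2 (Homo sapiens), read by scintillation counting, in the presence of a further agent that is not named here; on this read-out higher numbers stand for weaker inhibition and lower numbers for stronger inhibition: compound 1 `Cc1ccccc1CNc1nc2c(N)ncnc2n1[C@@H]1O[C@H](CO)[C@@H](O)[C@H]1O` with 65000 nM; compound 2 `CCCCCOC(=O)OC[C@H]1O[C@@H](n2cnc3c(N)ncnc32)[C@H](O)[C@@H]1O` with > 100000 nM; compound 3 `COc1cccc(CNc2nc3c(N)ncnc3n2[C@@H]2O[C@H](CO)[C@@H](O)[C@H]2O)c1` with 13000 nM.

Compound 2 stands apart from the other two: its reading is a limit of the assay and not a number, so where it truly lies is not known. That reading is the limit of > 100000 nM in this assay, at which 1 of the 3 values shown sits. Compound 4 `Nc1ncnc2c1ncn2[C@@H]1O[C@H](COC(=O)OCc2ccccc2)[C@@H](O)[C@H]1O` differs from compound 2 by phenyl in place of butyl on a saturated chain carbon bound to an oxygen next to a carbonyl group. Within the data shown here, the only measured step, a 5.0-fold lower number from compound 1 to compound 3 (0.70 log units; beyond the scatter), concerns a change at another place on a core unlike that of compound 2, so it does not bear on this change. Among the measured compounds shown here, with no guiding step and a starting point that is itself a limit, compound 4 is expected to stay weak, estimated at 100000 nM (range 30000 nM to 300000 nM), meaning an expected step of a number no higher from compound 2 to compound 4 (the limit leaves the size open).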

Compound 4, half-maximal inhibitory concentration: > 100000 nM
Compound 4: a limit, no number (the forecaster's own chance of this, stated with the estimate: 60%); the middle value lies on the limit itself.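

Compound 2 and compound 4 both give a limit and not a number, so no step between them can be read: the limit of > 100000 nM in this assay, at which 2 of the 4 values shown sit.

From the compounds shown here alone, whether phenyl in place of butyl changes the inhibition at all stays open.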